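Swapping One Group on the Longest-Lived Compound

This account rests on a few compounds, and the source may have more. Where it says the series, first, only, none or still open, it means among the compounds named here.

Compound 1 `CC(C)(C)c1ccc(C(=O)NCc2ccc(NS(=O)(=O)C3CC3)cc2Cl)cc1` gives 0.55 h
Compound 2 `CC(C)(C)c1ccc(C(=O)NCc2c(Cl)cc(NS(C)(=O)=O)cc2Cl)cc1` gives 1.37 h
Compound 3 `CS(=O)(=O)Nc1ccc(CNC(=O)c2ccc(C3(C(F)(F)F)CC3)cc2)c(Cl)c1` gives 3.03 h

These three values come from an ADME assay on microsomes from liver (Rattus norvegicus, strain Sprague-Dawley) for metabolic stability, read by HPLC, using NADPH, with stated times of 5 min and 60 min, tested at 10 uM (on this read-out higher numbers stand for a longer-lived compound and lower numbers for a shorter-lived compound), which follows how long a compound survives in the presence of liver enzymes. Compound 3 gives 3.03 h, the highest of the three numbers, and its gaps to the other two compounds both lie beyond the usual scatter. Compound 4 `CS(=O)(=O)Nc1ccc(CNC(=O)c2ccc(C34CC(C3)C4)cc2)c(Cl)c1` has not yet been measured. It keeps the core of compound 3 and changes one group, on an aromatic carbon of a six-membered aromatic ring of carbon only, para to a large group: a group of 5 heavy atoms (5 carbon; 2 four-membered non-aromatic rings of carbon only) in place of a group of 7 heavy atoms (4 carbon, 3 fluorine; one three-membered non-aromatic ring of carbon only), on an aromatic carbon. The 1-(trifluoromethyl)cyclopropyl group leaves, and a smaller group built from two four-membered rings of carbon takes its place.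

Among the measured compounds shown here, no two measured compounds differ in only one place, so nothing here shows directly what such a swap does. Compound 3 at 3.03 h already tops this small set, so a fall looks more likely than a further rise. The expected change is a 1.7-fold lower number from compound 3 to compound 4 (0.23 log units; within the scatter), a downward step that would stay within the usual scatter. Compound 4 is estimated at 1.8 h, with an expected range from 0.7 h to 4.5 h.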

Compound 4, half-life: 1.35 h
Compound 4: the middle estimate sits 1.3-fold (0.12 log units) above what was measured, and the stated range covers the measured number.
By their numbers in this assay, from the lowest: compound 1; then compounds 4 and 2 (each within the scatter of the next); then compound 3.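

In this assay, putting the group of 5 heavy atoms, built from two four-membered rings of carbon, in place of the 1-(trifluoromethyl)cyclopropyl group gives a 2.2-fold lower number from compound 3 to compound 4 (0.35 log units; beyond the scatter) on an otherwise unchanged compound. Among the compounds shown here, this is the first pair in the set that differs in one place only, so it gives the first direct reading of this position, and it shows that the group on this aromatic carbon, para to a large group, matters for half-life on this core. The earlier compounds differ from one another in more than one place and could not isolate this position, and although this pair ties the shorter half-life to the swap, nothing measured here explains it.

The compounds shown leave open how a nitrile, a methoxy group or a straight propyl chain at this same place would compare with the 1-(trifluoromethyl)cyclopropyl group. They also leave open whether the same swap would shift the half-life in the same direction on the other cores in this set, such as the core of compound 2.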